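Cyclopropylamino replacing 4-methylpiperazin-1-yl on the amide

The compounds below may be only part of what the source reports. "The series", "measured", "known", "first", "only" and "open" are said of these compounds alone.

Among the measured compounds shown here, compound 1 `CN1CCN(C(=O)/C=C/c2ccncc2-c2ccc3ccccc3c2)CC1` is one of two compounds measured in a functional assay on HCT-116 cells (Homo sapiens) for inhibition, read by MTT assay, with a stated time of 72 h; on this read-out lower numbers stand for stronger inhibition of growth and higher numbers for weaker inhibition of growth. In this assay compound 1 reaches only the limit > 30000 nM, so no number is known for it. Compound 2 `O=C(/C=C/c1ccncc1-c1ccc2cc[nH]c2c1)N1CCOCC1` likewise gives only the limit > 30000 nM in this assay. Both measurements share (the limit of > 30000 nM in this assay, at which 2 of the 2 values shown sit). Compound 3 `O=C(/C=C/c1ccncc1-c1ccc2ccccc2c1)NC1CC1` is not yet measured; the change from compound 1 to compound 3 is cyclopropylamino in place of 4-methylpiperazin-1-yl on a carbonyl carbon. For the measured compounds named here, no measured pair differs in one place, so the size of this change cannot be read from the data. The step of a number no higher from compound 1 to compound 3 (the limit leaves the size open) is expected to be none beyond the scatter. Compound 3 is estimated at 30000 nM, between 6000 nM and 100000 nM.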

Compound 3, concentration for 50% growth inhibition: 6180 nM
Estimate against measurement, compound 3: 4.9-fold (0.69 log units) above; measured number inside the range.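

In this assay, among the compounds shown here, the group on the carbonyl carbon proves able to shift growth inhibition: cyclopropylamino in place of 4-methylpiperazin-1-yl gives an at least 4.8-fold lower number from compound 1 to compound 3 (0.68 log units; beyond the scatter), and compound 3 is the first compound here with a real number. The full size of this step stays unknown, since compound 1 has only a limit: the limit of > 30000 nM in this assay, at which 2 of the 3 values shown sit.

The change removes the piperazine ring and adds the amide hydrogen at once, so the compounds shown cannot say which part counts. Dimethylamino on the same carbonyl carbon, with no ring and no amide hydrogen, would begin to separate the two.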